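Five-membered ring swaps on the shared spiro-lactam core

The compounds below may be only part of what the source reports. "The series", "measured", "known", "first", "only" and "open" are said of these compounds alone.

Measured in a functional assay on MV4-11 cells (Homo sapiens) for inhibition, read by resazurin assay, with a stated time of 72 h; on this read-out higher numbers stand for weaker inhibition of growth and lower numbers for stronger inhibition of growth:
- compound 1 `O=C1NCCC12CCN(c1c(Cl)cncc1-c1ccco1)CC2`: 940 nM
- compound 2 `O=Cc1ccc(-c2cncc(Cl)c2N2CCC3(CCNC3=O)CC2)s1`: 750 nM

Among the compounds with values here, compound 1 stands highest of the two numbers measured so far. Within the data shown here, its nearest neighbour is compound 2, and the one step available, a 1.3-fold lower number from compound 1 to compound 2 (0.10 log units; within the scatter), is 5-formylthiophen-2-yl in place of furan-2-yl on an aromatic carbon. That step lies within the scatter, so the two compounds cannot be ordered on these numbers.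

Compound 3 `Cn1cccc1-c1cncc(Cl)c1N1CCC2(CCNC2=O)CC1` is not yet measured. Relative to compound 1 the change is 1-methyl-1H-pyrrol-2-yl in place of furan-2-yl on an aromatic carbon. Among the measured compounds shown here, no measured pair shows 1-methyl-1H-pyrrol-2-yl entering at this position, so the only step that bears on it is a 1.3-fold lower number from compound 1 to compound 2 (0.10 log units; within the scatter), where another five-membered aromatic ring replaced furan-2-yl at the same carbon without a shift beyond the scatter. By analogy, the step expected from compound 1 to compound 3 is a 1.0-fold lower number from compound 1 to compound 3 (0.02 log units; within the scatter), that is, nothing beyond the scatter in either direction. For the measured compounds named here, compound 3 is therefore estimated at 900 nM in this assay, with a range of 300 nM to 2800 nM reflecting the single relevant step.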

Compound 3, concentration for 50% growth inhibition: 900 nM
The estimate for compound 3 equals the measured number at the digits printed, within the range that was stated.
By their numbers in this assay, from the lowest: compounds 2, 3 and 1 (each within the scatter of the next).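

In this assay, 1-methyl-1H-pyrrol-2-yl in place of furan-2-yl gives a 1.0-fold lower number from compound 1 to compound 3 (0.02 log units; within the scatter) at this carbon, so a ring with nitrogen as its hetero atom, one heavy atom larger than furan-2-yl, adds a third five-membered aromatic ring with no shift beyond the scatter. Within the data shown here, the comparison with the formyl-bearing ring reads the same way, with a 1.2-fold higher number from compound 2 to compound 3 (0.08 log units; within the scatter) for 1-methyl-1H-pyrrol-2-yl in place of 5-formylthiophen-2-yl, so the three rings cannot be ordered and the series so far shows a flat response to these swaps. No evidence at hand bears on this flat response.

The compounds shown carry only five-membered aromatic rings at this carbon, so it stays open whether a phenyl ring, an aminomethyl group or a carboxylic acid there would move the number beyond the scatter. The chloro group and the shared core are also the same throughout, which leaves the effect of any change at those places open.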